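Swapping the group on a carbonyl carbon

A few compounds are considered here, and "the series" means these few. Any claim that something is new, unique, unknown or untested is made for them only; others in the source may bear on it.

- compound 1 `O=C(N[C@H]1CN(S(=O)(=O)c2ccccc2)C[C@@H]1C(=O)N[C@H]1CCCNC1)c1cc(-c2ccccc2Cl)on1` gives 1.9
- compound 2 `O=C(N[C@H]1CN(S(=O)(=O)c2ccccc2)C[C@@H]1C(=O)N1C[C@H]2CCNC[C@H]21)c1cc(-c2ccccc2Cl)on1` gives 1.7

Among the compounds with values here, both values come from a physicochemical assay for lipophilicity, measured as octanol-water partition, at pH 7.4 (on this read-out lower numbers stand for lower lipophilicity and higher numbers for higher lipophilicity), and lie within the usual scatter of each other: compound 2 stands at 1.7 on this scale, with compound 1 as its only neighbour. The next molecule, compound 3 `O=C(N[C@H]1CN(S(=O)(=O)c2ccccc2)C[C@@H]1C(=O)NC[C@@H]1CCCN1)c1cc(-c2ccccc2Cl)on1`, keeps the shared core and changes one place, on a carbonyl carbon (a group of 7 heavy atoms (5 carbon, 2 nitrogen; one five-membered non-aromatic ring with 1 hetero atom) in place of a group of 8 heavy atoms (6 carbon, 2 nitrogen; one four-membered non-aromatic ring with 1 hetero atom, one six-membered non-aromatic ring with 1 hetero atom), on a carbonyl carbon). There a ((pyrrolidin-2-yl)methyl)amino group enters. Within the data shown here, only one measured step also exchanges the group on that carbonyl carbon (a number 0.20 log units lower from compound 1 to compound 2 (within the scatter)). Resting on that single small step, no change beyond the scatter is expected in this assay here, in either direction. The step expected on this estimate is a number 0.10 log units higher from compound 2 to compound 3 (within the scatter) in size. For compound 3 the estimated value is 1.8 (expected range 1.3 to 2.3).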

Compound 3, distribution coefficient: 1.5
Compound 3: the middle estimate sits 0.30 log units above what was measured, and the stated range covers the measured number.
By their numbers in this assay, from the lowest: compounds 3, 2 and 1 (each within the scatter of the next, the first and the last beyond it).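

In this assay, within the data shown here, putting (pyrrolidin-2-yl)methyl in place of piperidin-3-yl on an amide-type nitrogen gives the first step at this position that clears the usual scatter (a number 0.40 log units lower from compound 1 to compound 3 (beyond the scatter)), although the step is modest. The two groups have the same count of heavy atoms, so rearranging those atoms, rather than adding any, is enough to move the number, while the comparison with the fused two-ring group stays inside the scatter (a number 0.20 log units lower from compound 2 to compound 3 (within the scatter)). No measurement at hand explains why the number moves.

The compounds shown leave open whether the step follows the smaller ring or the methyl link that joins it to the nitrogen. A pyrrolidin-3-yl group on that same nitrogen, which has the five-membered ring without the methyl link, would help separate the two.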